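Swapping the pyridine substituent on a potassium channel inhibitor

A few compounds are considered here, and "the series" means these few. Any claim that something is new, unique, unknown or untested is made for them only; others in the source may bear on it.

Measured so far:
- compound 1 `C[C@@H](c1nc(-c2cccc(F)c2)no1)N(C)C(=O)c1cc(C(F)(F)F)nn1C`: 6490 nM
- compound 2 `Cc1cncc(-c2noc([C@H](C)NC(=O)c3cc(C(F)(F)F)nn3C)n2)c1`: 1370 nM

In an assay on T-REx-293 cells for inhibition of potassium channel subfamily T member 1 (Homo sapiens), read by patch clamp (on this read-out lower numbers stand for stronger inhibition and higher numbers for weaker inhibition), compound 2 gives the lower of the two numbers shown, and compound 1 sits a clear step higher, beyond the scatter. Compound 3 `COc1cc(-c2noc([C@H](C)NC(=O)c3cc(C(F)(F)F)nn3C)n2)cc(C)n1` is not yet measured. It differs from compound 2 in one place: 2-methoxy-6-methylpyridin-4-yl in place of 5-methylpyridin-3-yl on an aromatic carbon. Within the data shown here, no single-change step between measured compounds is available, so the outlook rests on compound 2 alone. The step of a 1.4-fold lower number from compound 2 to compound 3 (0.14 log units; within the scatter) is expected to stay within the scatter. Compound 3 is estimated at 1000 nM, with a likely range from 300 nM to 3500 nM.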

Compound 3, half-maximal inhibitory concentration: 505 nM
For compound 3 the middle estimate is 2.0-fold (0.30 log units) above the measured one; measured number inside the range.
By their numbers in this assay, from the lowest: compound 3; then compound 2; then compound 1.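

In this assay, the aromatic carbon between two ring nitrogen atoms responds to the group it carries: 2-methoxy-6-methylpyridin-4-yl in place of 5-methylpyridin-3-yl gives a 2.7-fold lower number from compound 2 to compound 3 (0.43 log units; beyond the scatter) and shows that a larger pyridine group is accepted here. No measurement shown accounts for this gain.

As far as these compounds go, the methoxy group and the new arrangement of the pyridine ring arrive together, so their separate shares remain unknown. From the compounds shown here alone, whether an ethoxy group or an amine in place of the methoxy group would keep the lower number also stays open.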